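The source may hold more compounds than are shown below. What is called first, only, known or untested is meant among the compounds shown, and "the series" means these compounds.

Measured compounds:
Compound 1, `Cc1ccc(OC(=O)/C=C/c2ccc(Cl)cc2Cl)c(C(C)C)c1`: 32%
Compound 2, `Cc1ccc(OC(=O)/C=C/c2ccc(Cl)cc2)c(C(C)C)c1`: 41%

In a functional assay on the whole organism for inhibition, with Brassica rapa subsp. chinensis as the target, with a stated time of 3 days, tested at 100 ppm (a higher number here means more inhibition of growth at the concentration tested, a lower number less inhibition of growth), compound 2 gives 41%. Compound 2 stands alongside compound 1, since the step of a number 9 percentage points higher from compound 1 to compound 2 (within the scatter) lies within the scatter, so the two compounds cannot be told apart on these numbers. Compound 3, `Cc1ccc(OC(=O)/C=C/c2ccc(C(C)C)cc2)c(C(C)C)c1`, differs from compound 2 by isopropyl in place of chloro on an aromatic carbon. Among the measured compounds shown here, the only measured step, a number 9 percentage points higher from compound 1 to compound 2 (within the scatter), concerns a chloro giving way to hydrogen and stayed within the scatter; no measured step shows an isopropyl entering at this place, so the data give no direct guide. For the measured compounds named here, the single step at hand suggests that a change at this group moves the number little, so the expected step of a number 3 percentage points lower from compound 2 to compound 3 (within the scatter) is none beyond the scatter. Compound 3 is therefore expected to give about 38%, with a range from 15% to 60%.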

Compound 3, percent growth inhibition at one concentration: 39%
Estimate against measurement, compound 3: 1 percentage points below; the measured number falls inside the stated range.
By their numbers in this assay, from the lowest: compounds 1, 3 and 2 (each within the scatter of the next).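

In this assay, among the compounds shown here, the step of a number 2 percentage points lower from compound 2 to compound 3 (within the scatter) is the first to put a carbon group at this place, on an aromatic carbon para to a large group, and an isopropyl of 3 heavy atoms cannot be told apart from a chloro of 1 heavy atom there. For the compounds shown here, the only earlier step, a number 9 percentage points higher from compound 1 to compound 2 (within the scatter) involved a chloro giving way to hydrogen, so it said nothing about a larger group at this place. No measurement at hand gives a reason for this result.

As far as these compounds go, it stays open whether an amine, a carboxylic acid or a methoxy group at this place would also stay within the scatter of compound 2. The compounds shown also leave open how a longer chain, such as a hexyl group, would fare here.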